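The source may report more compounds than this note shows. Statements on the series, on what has been measured and on what is new or still open speak of the compounds shown alone.

Measured compounds: compound 1 `C=C(c1ccc[nH]1)N(C)Cc1ccccc1` with 3500 nM; compound 2 `C=C(c1cccn1C)N(C)Cc1ccccc1` with 150 nM; compound 3 `CN(Cc1ccccc1)C(=O)c1ccc[nH]1` with 600 nM.

The three were measured in an assay on mitochondria from brain for inhibition of Amine oxidase [flavin-containing] A (Bos taurus); a higher number here means a weaker inhibitor, a lower number a stronger inhibitor. Compound 1 and compound 2 share a core and differ by one change, (methyl in place of hydrogen on an aromatic nitrogen), and that single change produced a 23-fold lower number from compound 1 to compound 2 (1.37 log units; beyond the scatter). Compound 3 carries a different core; how its core differs from that of compound 1 is not broken down here, and their values alone show that compound 3 gives a lower number than compound 1 in this assay.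

Compound 4 `CN(Cc1ccccc1)C(=O)c1cccn1C` has not yet been measured. Compound 4 arises from compound 3 by methyl in place of hydrogen on an aromatic nitrogen, which is the same change, in the same place on the same kind of ring, as that from compound 1 to compound 2. If the step carries over to the core of compound 3, a step of about a 15-fold lower number from compound 3 to compound 4 (1.18 log units; beyond the scatter) is expected, resting on the large step of a 23-fold lower number from compound 1 to compound 2 (1.37 log units; beyond the scatter) and on the value of compound 3, 600 nM. The shift is taken as somewhat smaller than the earlier one, since the two cores differ. Compound 4 is therefore estimated at 40 nM in this assay, with a range from 10 nM to 200 nM.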

Compound 4, inhibition constant: 340 nM
For compound 4 the middle estimate is 8.5-fold (0.93 log units) below the measured one; measured number above the stated range.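

In this assay, methyl in place of hydrogen on the aromatic nitrogen gave a small step on the core of compound 3 (a 1.8-fold lower number from compound 3 to compound 4 (0.25 log units; within the scatter)), and no effect of the methyl can be told apart from the scatter on this core. The step did not carry over from one core to the other at its earlier size: the same change on two cores in this assay, a 23-fold lower number (1.37 log units; beyond the scatter) from compound 1 to compound 2 and a 1.8-fold lower number (0.25 log units; within the scatter) from compound 3 to compound 4, 13-fold (1.12 log units) apart, beyond the scatter of two such steps. This shows that the large step on the core of compound 1 cannot be treated as a fixed property of the change in this series, but two pairs do not show which difference between the cores goes with the gap, nor what the change would give on a further core.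

The compounds shown leave open what a longer chain, such as ethyl, would give in place of the methyl on the aromatic nitrogen. They also leave open whether an amine or a carboxylic acid elsewhere on either core would alter the step seen with the methyl.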